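Shortening the Side Chain of a Kinase Inhibitor

This account rests on a few compounds, and the source may have more. Where it says the series, first, only, none or still open, it means among the compounds named here.

Three amides built on one shared core have been measured in an assay on isolated protein for inhibition of Rho-associated protein kinase 2 (Homo sapiens); on this read-out lower numbers stand for stronger inhibition and higher numbers for weaker inhibition. Compound 3 `CC(C)C[C@H](N)C(=O)Nc1cc2cc[nH]c(=O)c2cc1Cl` gives 340 nM, the lowest number among the three. Compound 1 `N[C@@H](C(=O)Nc1cc2cc[nH]c(=O)c2cc1Cl)C1CCCCC1` gives 400 nM, which lies within the usual scatter of the number for compound 3, so the two cannot be ranked against each other. Compound 2 `CC(C)(C)C[C@H](N)C(=O)Nc1cc2cc[nH]c(=O)c2cc1Cl` gives 845 nM, the highest number shown. Among the measured compounds shown here, the only single-point step between measured compounds is a 2.5-fold lower number from compound 2 to compound 3 (0.40 log units; beyond the scatter), in which a methyl on a saturated chain carbon bound to three saturated chain carbons is replaced by hydrogen.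

Compound 4 `CC(C)[C@@H](N)C(=O)Nc1cc2cc[nH]c(=O)c2cc1Cl` has not yet been measured. It differs from compound 3 by 1-amino-2-methylpropyl in place of 1-amino-3-methylbutyl on a carbonyl carbon, the entering group being the shorter of the two. For the measured compounds named here, no measured step shortens the chain in this way; the step from compound 2 to compound 3 only trims a methyl from the branch, and compound 1, with a ring in place of the chain, gives a number within the scatter of that of compound 3. Since those changes moved the number modestly or not at all, only a small step in this assay is expected for compound 4, with a slight lean toward a higher number. Compound 4 is therefore estimated at 450 nM, within 170 nM to 1200 nM, which would mean a step of a 1.3-fold higher number from compound 3 to compound 4 (0.12 log units; within the scatter).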

Compound 4, half-maximal inhibitory concentration: 240 nM
The estimate for compound 4 lay 1.9-fold (0.27 log units) above the measured number, within the range that was stated.
By their numbers in this assay, from the lowest: compounds 4, 3 and 1 (each within the scatter of the next); then compound 2.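

In this assay, among the compounds shown here, the shorter 1-amino-2-methylpropyl on the carbonyl carbon gives a 1.4-fold lower number from compound 3 to compound 4 (0.15 log units; within the scatter), so this shortening of the chain produces no step that can be told from ordinary repeat variation. Swapping the ring for a small branch tells the same story, with isopropyl in place of cyclohexyl on the saturated chain carbon bound to an amine nitrogen and a carbonyl carbon giving a 1.7-fold lower number from compound 1 to compound 4 (0.22 log units; within the scatter), which means that this position accepts a cyclohexyl group, a 1-amino-3-methylbutyl chain and a 1-amino-2-methylpropyl chain without a readable change in the number. The exception among these four compounds is the bulkiest chain, 1-amino-3,3-dimethylbutyl, since replacing it with 1-amino-2-methylpropyl gives a 3.5-fold lower number from compound 2 to compound 4 (0.55 log units; beyond the scatter), a modest step that lies beyond the scatter.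

Nothing shown here explains why that one chain stands apart from the other three groups.
Going by these compounds, it also remains open whether the number would hold with a still smaller group such as 1-aminoethyl, with a flat ring such as phenyl, or with a carboxylic acid on the chain in place of the amine.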